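Compound 4 in a series without a measured number

This account rests on a few compounds, and the source may have more. Where it says the series, first, only, none or still open, it means among the compounds named here.

In a functional assay on Raji cells (Homo sapiens) for cytotoxicity, with a stated time of 72 h (a lower number here means that less compound is needed, a higher number that more compound is needed for the effect), compound 1 `C=C[C@@](C)(/C=C/c1ccc(O)cc1)CC/C=C/C#N` reads > 26000 nM as a limit of the assay and not a number. Compound 3 `C=C[C@@](C)(/C=C/c1ccc(O)c(/C=C/C(=O)NCc2ccc(C(F)(F)F)cc2)c1)CCC=C(C)C` reads > 26000 nM and this too is only a limit. Compound 2 `C=C[C@@](C)(/C=C/c1ccc(O)c(/C=C/C(=O)c2ccccc2)c1)CCC=C(C)C` reads > 26000 nM and is therefore also known only as a limit, so it has no numerical place in the series.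

Compound 4 `C=C[C@@](C)(/C=C/c1ccc(O)c(/C=C/c2ccc(Cl)c(Cl)c2)c1)CCC=C(C)C` has not yet been measured. Its difference from compound 2 is 3,4-dichlorophenyl in place of benzoyl on a double-bonded chain carbon bound to a double-bonded chain carbon and this places 3,4-dichlorophenyl where benzoyl stood. Going by the values given here, no step between measured compounds is available to size this change. Among the compounds with values here, the only guide in this assay is the limit of > 26000 nM in this assay, at which 3 of the 3 values shown sit, and no compound yet gives a number to work from. The estimated step of a number no higher from compound 2 to compound 4 (the limit leaves the size open) is therefore expected to be none beyond the scatter, in either direction. Compound 4 is estimated at 26000 nM with an expected range of 12000 nM to 52000 nM and an outcome that is only a limit of the assay is expected to be the likelier one.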

Compound 4, half-maximal effective concentration: > 26000 nM
Compound 4: only a limit was reported; the forecaster's own chance of this, stated with the estimate: 70%; the middle value lies on the limit itself.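

Compound 2 and compound 4 are each known only as a limit of the assay, so no step between them can be read: the limit of > 26000 nM in this assay, at which 4 of the 4 values shown sit.

The compounds shown leave open whether 3,4-dichlorophenyl in place of benzoyl changes anything in this assay, and what number any compound in the series would give.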